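The compounds below may be only part of what the source reports. "The series", "measured", "known", "first", "only" and "open" are said of these compounds alone.

Measured so far:
compound 1 `CN(C)CCn1ccc2cc(NS(=O)(=O)c3cccc4ccccc34)ccc21` gives 94.2 nM
compound 2 `Cc1cc2cc(NS(=O)(=O)c3cccc4ccccc34)ccc2n1CCN(C)C` gives 124 nM

Both numbers come from an assay on HEK293 cells for binding affinity to 5-hydroxytryptamine receptor 6 (Homo sapiens); a lower number here means a stronger inhibitor, a higher number a weaker inhibitor. Among the compounds with values here, compound 1 has the lowest of the two numbers, but its only neighbour lies close: the step of a 1.3-fold higher number from compound 1 to compound 2 (0.12 log units; within the scatter) is within the scatter, so the two values cannot be told apart on this evidence, and neither compound can be called the stronger one.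

Compound 3 `CCN(CC)CCn1ccc2cc(NS(=O)(=O)c3cccc4ccccc34)ccc21` has not yet been measured in this assay. It differs from compound 1 in one place: diethylamino in place of dimethylamino on a saturated chain carbon, two bonds along the chain from an aromatic nitrogen. Within the data shown here, the single measured step, from compound 1 to compound 2, concerns a different kind of change at a different place, a methyl in place of hydrogen on an aromatic carbon rather than a larger amine at the end of the chain, and that step was itself within the scatter. It therefore offers no direct guide to the present change, and nothing in the data points in either direction.

The expected step is accordingly a 1.6-fold higher number from compound 1 to compound 3 (0.20 log units; within the scatter), not reaching beyond the scatter, though the uncertainty is wide. Compound 3 is thus estimated at 150 nM, with a range from 50 nM to 450 nM.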

Compound 3, inhibition constant: 116 nM
Compound 3: the middle estimate sits 1.3-fold (0.11 log units) above what was measured; the range from low to high includes it.
By their numbers in this assay, from the lowest: compounds 1, 3 and 2 (each within the scatter of the next).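

In this assay, within the data shown here, the step of a 1.2-fold higher number from compound 1 to compound 3 (0.09 log units; within the scatter) is the first measured change at the amine end of the chain, and it lies within the scatter, so compound 1 and compound 3 cannot be told apart. The earlier step concerned a methyl on an aromatic carbon, so it said nothing about this place; here, enlarging the amine from dimethylamino to diethylamino, from 3 heavy atoms to 5, produces no difference that can be resolved from the number alone. No supporting measurement is available to explain this result.

From the compounds shown here alone, this is a single pair, so it remains open whether the same holds for a bulkier or differently shaped amine at this place, such as a pyrrolidine or piperidine ring, or for a primary amine carrying no alkyl groups at all. It also leaves open what a longer chain between the aromatic nitrogen and the amine would do, and whether diethylamino behaves the same way on compound 2, which carries the extra methyl.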